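Tetrazolyl in Place of Triazolyl in a Cytotoxicity Pair

The source may report more compounds than this note shows. Statements on the series, on what has been measured and on what is new or still open speak of the compounds shown alone.

Measured so far:
Compound 1, `O=C(CSc1nnnn1-c1ccccc1)N/N=c1/scc(-c2ccc(Br)cc2)n1-c1ccccc1`: 58.6%
Compound 2, `Cn1cnnc1SCC(=O)N/N=c1/scc(-c2ccc(C#N)cc2)n1-c1ccccc1`: 62.6%

In a functional assay on C6 cells (Rattus norvegicus) for cytotoxicity, read by MTT assay, with a stated time of 24 h, tested at 12 ug/mL (a higher number here means a weaker effect of the compound at the concentration tested, a lower number a stronger effect), compound 2 and compound 1 lie within the scatter of each other, so the two numbers show no separation. Compound 3, `N#Cc1ccc(-c2cs/c(=N/NC(=O)CSc3nnnn3-c3ccccc3)n2-c2ccccc2)cc1`, is not yet measured. It differs from compound 2 in one place: 1-phenyl-1H-tetrazol-5-yl in place of 4-methyl-4H-1,2,4-triazol-3-yl on a sulfur. For the measured compounds named here, the two measured compounds differ from each other in two places, so no single step is known. Compound 3 is expected to stay close to compound 2, with a step of a number 2.6 percentage points lower from compound 2 to compound 3 (within the scatter) of no size beyond the scatter. The estimate for compound 3 is 60%, in the range 46% to 74%.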

Compound 3, a percentage reported as activity, at one concentration (the size of the read-out at that concentration, not a potency): 74.1%
Compound 3: middle estimate off by 14.1 percentage points, on the low side; measured number outside the range, above it.
By their numbers in this assay, from the lowest: compounds 1 and 2 (each within the scatter of the next); then compound 3.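

In this assay, the group on the sulfur proves able to shift the read-out: 1-phenyl-1H-tetrazol-5-yl in place of 4-methyl-4H-1,2,4-triazol-3-yl gives a number 11.5 percentage points higher from compound 2 to compound 3 (beyond the scatter) and so a weaker effect. The aromatic carbon also counts, since with the tetrazolyl group held fixed, cyano in place of bromo gives a number 15.5 percentage points higher from compound 1 to compound 3 (beyond the scatter) and again a weaker effect. Nothing available explains either step.

Going by these compounds, each step rests on a single pair, so whether the change from bromo to cyano acts alike with the triazolyl group stays open. On these data alone, what an amine on that aromatic carbon would do also remains open.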